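This account rests on a few compounds, and the source may have more. Where it says the series, first, only, none or still open, it means among the compounds named here.

Compound 1 `Oc1ccc(CNc2cc(C(F)(F)F)cc3[nH]ncc23)cc1` is measured in an assay for inhibition of Indoleamine 2,3-dioxygenase 1 (Homo sapiens), with stated times of 10 min and 60 min (a lower number here means a stronger inhibitor, a higher number a weaker inhibitor), where compound 1 gives 36700 nM. Among the two numbers shown it is the higher one. Compound 2 `FC(F)(F)c1cc(NC[C@H]2CCCN2)c2cn[nH]c2c1` gives 9580 nM in this assay, and the step from compound 1 to compound 2 a 3.8-fold lower number from compound 1 to compound 2 (0.58 log units; beyond the scatter) is a modest gain. Compound 3 `O=[N+]([O-])c1cc(OCc2ccccc2)ccc1CNc1cc(C(F)(F)F)cc2[nH]ncc12` gives > 100000 nM in this assay, which is a limit of the assay and not a number (the limit of > 100000 nM in this assay, at which 1 of the 3 values shown sits).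

Compound 4 `Oc1ccc(CNc2cc(C(F)(F)F)cc3[nH]ncc23)c(Cl)c1` differs from compound 1 in one place: chloro in place of hydrogen on an aromatic carbon. Among the measured compounds shown here, none of the measured steps involves a change of this kind; the step to compound 2 replaces the whole 4-hydroxyphenyl group, and compound 3 carries other groups on a different ring. For the measured compounds named here, no measured step therefore bears directly on adding a chloro group here, and a step within the usual scatter, in either direction, is expected in this assay for the change from compound 1 to compound 4 a 1.5-fold lower number from compound 1 to compound 4 (0.17 log units; within the scatter). Compound 4 is thus expected to give about 25000 nM, somewhere between 8000 nM and 80000 nM.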

Compound 4, half-maximal inhibitory concentration: 6020 nM
Estimate against measurement, compound 4: 4.2-fold (0.62 log units) above; the measured number lies below the stated range.
By their numbers in this assay, from the lowest: compounds 4 and 2 (each within the scatter of the next); then compound 1. At a limit, above all of these: compound 3.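

Placing one chloro on an aromatic carbon of a six-membered aromatic ring of carbon only, ortho to a large group and meta to a hydroxy group, gives a 6.1-fold lower number from compound 1 to compound 4 (0.79 log units; beyond the scatter) in this assay. Among the compounds shown here, this is the first sign that the number responds to a change on this ring while the 4-hydroxyphenyl group otherwise stays in place, whereas the earlier single-place step replaced that whole group. Nothing measured among these compounds accounts for the size of this step.

From the compounds shown here alone, whether this step is particular to chloro, or would also follow from a fluoro, a methyl or a methoxy group on the same carbon, stays open. Also open is how chloro would act on the other aromatic carbons of this ring, since this one position is the only one shown for it.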